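Shortening the side chain on the oxadiazole amine

A few compounds are considered here, and "the series" means these few. Any claim that something is new, unique, unknown or untested is made for them only; others in the source may bear on it.

Measured compounds:
Compound 1, `CCC(Nc1nnc(-c2ccc(OC)cc2)o1)[C@H]1CC[C@@H](c2ccnc3ccc(F)cc32)CC1`: 6 nM
Compound 2, `CCOCC(Nc1nnc(-c2ccc(OC)cc2)o1)[C@H]1CC[C@@H](c2ccnc3ccc(C(F)(F)F)cc32)CC1`: 13 nM
Compound 3, `COc1ccc(-c2nnc(N[C@H](C)[C@H]3CC[C@@H](c4ccnc5ccc(F)cc54)CC3)o2)cc1`: 3 nM

In an assay on tissue (HeLa cells) for inhibition of Indoleamine 2,3-dioxygenase 1 (Homo sapiens), read by fluorescence, with a stated time of 18 h (on this read-out higher numbers stand for weaker inhibition and lower numbers for stronger inhibition), compound 2 gives 13 nM, the highest of the three numbers shown. The nearest is compound 1 with 6 nM, a gap that lies beyond the scatter, and the furthest is compound 3 with 3 nM, also beyond the scatter. Compound 2 thus stands as the weakest inhibitor of the three.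

The unmeasured compound 4, `CCC(Nc1nnc(-c2ccc(OC)cc2)o1)[C@H]1CC[C@@H](c2ccnc3ccc(C(F)(F)F)cc32)CC1`, differs from compound 2 in one place: methyl in place of ethoxy on a saturated chain carbon, two bonds along the chain from a nitrogen on an aromatic ring and a saturated ring carbon. Read one bond further out, the ethoxymethyl chain becomes an ethyl chain, the chain found in compound 1, although compound 1 and compound 4 still differ in a second place and no single step connects them. Because compound 1 reaches 6 nM with the ethyl chain, a modest move toward lower numbers is expected for compound 4 in this assay, and the expected step is a 1.9-fold lower number from compound 2 to compound 4 (0.27 log units; within the scatter), possibly no larger than the scatter. Compound 4 is therefore estimated at 7 nM, within a range from 3 nM to 16 nM.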

Compound 4, half-maximal inhibitory concentration: 3 nM
The estimate for compound 4 lay 2.3-fold (0.37 log units) above the measured number; measured number inside the range.
By their numbers in this assay, from the lowest: compounds 3, 4 and 1 (each within the scatter of the next); then compound 2.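

In this assay, the ethoxy on the saturated chain carbon now has a single-place reading: methyl in its place gives a 4.3-fold lower number from compound 2 to compound 4 (0.64 log units; beyond the scatter), a step beyond the scatter. With the chain held as ethyl, trifluoromethyl in place of fluoro on an aromatic carbon gives a 2.0-fold lower number from compound 1 to compound 4 (0.30 log units; within the scatter), so these two groups cannot be told apart here, and trifluoromethyl alone does not go with the high number of compound 2. Nothing at hand gives a reason for either step.

Going by these compounds, whether a hydroxyl, an amine or a longer alkyl chain at this carbon would read like ethoxy or like methyl remains open. Also open, on these data alone, is whether ethoxy gives a step of similar size when fluoro stands on the aromatic carbon.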